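A few compounds are considered here, and "the series" means these few. Any claim that something is new, unique, unknown or untested is made for them only; others in the source may bear on it.

Values in a functional assay on A549 cells (Homo sapiens) for antiproliferative activity, read by MTT assay, with a stated time of 72 h; on this read-out lower numbers stand for stronger inhibition and higher numbers for weaker inhibition:
- Compound 1 `C#Cc1cccc(Nc2ncnc3cc(OC)c(OCCCN4CCNCCNCC4)cc23)c1`: > 50000 nM, a limit of the assay
- Compound 2 `COc1cc2ncnc(Nc3cccc(Br)c3)c2cc1OCCCN1CCNCCNCC1`: 34300 nM
- Compound 3 `COc1cc2ncnc(Nc3ccc(Br)cc3F)c2cc1OCCCN1CCNCCNCC1`: 16100 nM

Of the two actual numbers in this assay, compound 3 has the lower, at 16100 nM. Compound 4 `COc1cc2ncnc(Nc3ccc(Cl)c(C(F)(F)F)c3)c2cc1OCCCN1CCNCCNCC1` keeps the shared core and side chain and exchanges only the group on the nitrogen: 4-chloro-3-(trifluoromethyl)phenyl in place of 4-bromo-2-fluorophenyl on a nitrogen on an aromatic ring. Two measured steps changed this same group, and both end at the same compound. The first is a 2.1-fold lower number from compound 2 to compound 3 (0.33 log units; beyond the scatter). The second, which starts from a limit, is an at least 3.1-fold lower number from compound 1 to compound 3 (0.49 log units; beyond the scatter). Neither step shows which way the new group will move the number, so only a small change is expected. The expected step is a 1.1-fold higher number from compound 3 to compound 4 (0.05 log units; within the scatter). Compound 4 is estimated at 18000 nM, with an expected range from 7000 nM to 45000 nM.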

Compound 4, half-maximal inhibitory concentration: 6230 nM
Compound 4: the middle estimate sits 2.9-fold (0.46 log units) above what was measured; the whole stated range lies above it.
By their numbers in this assay, from the lowest: compound 4; then compound 3; then compound 2. At a limit, above all of these: compound 1.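

Going by these compounds alone, at this position on the nitrogen, 4-chloro-3-(trifluoromethyl)phenyl gives the lowest number so far, with a 2.6-fold lower number from compound 3 to compound 4 (0.41 log units; beyond the scatter) and a 5.5-fold lower number from compound 2 to compound 4 (0.74 log units; beyond the scatter). The number therefore still responds to changes in this aryl group, and the new group, the largest shown here, does not raise it. The third comparison, an at least 8.0-fold lower number from compound 1 to compound 4 (0.90 log units; beyond the scatter), gives only a floor, as it starts from a limit: the limit of > 50000 nM in this assay, at which 1 of the 4 values shown sits.

Chloro and trifluoromethyl enter together, so the share of each stays open. From the compounds shown here alone, how a ring carrying a nitrile or a methoxy group would compare also remains unknown.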